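The compounds below may be only part of what the source reports. "The series", "measured", "known", "first", "only" and "open" are said of these compounds alone.

Of the compounds shown here, two sharing one core have been measured in a functional assay on MCF7 cells (Homo sapiens) for antiproliferative activity, with a stated time of 5 days; a higher number here means a weaker inhibitor, a lower number a stronger inhibitor. Compound 1 (`COc1ccc(-c2[nH]c3ccc(C)cc3c2C=O)cc1`) gives 140 nM, and compound 2 (`COc1ccc(-c2[nH]c3ccc(C(C)(C)C)cc3c2C=O)cc1`) gives 580 nM, which is the higher of the two numbers and makes it the weaker inhibitor of the pair. Compound 3 (`CCCCCCc1ccc2[nH]c(-c3ccc(OC)cc3)c(C=O)c2c1`) departs from compound 2 at the substituent that separates the measured pair, with hexyl in place of tert-butyl on an aromatic carbon. For the measured compounds named here, only one measured step bears on this change. That step, a 4.1-fold higher number from compound 1 to compound 2 (0.62 log units; beyond the scatter), is modest but beyond the scatter, and it replaces methyl with tert-butyl on that same carbon. It shows a larger group going with a higher number, but it rests on a single pair, and no straight chain longer than methyl has been measured. A step in the same direction, and somewhat smaller, is therefore expected in this assay, although the data cannot exclude a step lost in the scatter. The expected step is a 2.2-fold higher number from compound 2 to compound 3 (0.35 log units; beyond the scatter). For compound 3 the estimated value is 1300 nM, within an expected range from 400 nM to 4000 nM.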

Compound 3, half-maximal inhibitory concentration: 6 nM
Compound 3: the middle estimate sits 220-fold (2.34 log units) above what was measured; the whole stated range lies above it.
By their numbers in this assay, from the lowest: compound 3; then compound 1; then compound 2.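

In this assay, this position on the aromatic carbon does not follow the direction suggested by the first pair: hexyl in place of tert-butyl gives a 97-fold lower number from compound 2 to compound 3 (1.99 log units; beyond the scatter) and is a large step, even though hexyl is the bigger group. Measured against the small methyl group as well, the straight chain gives a 23-fold lower number from compound 1 to compound 3 (1.37 log units; beyond the scatter) and is again a large step, so across these three compounds the number does not simply rise with group size, and compound 3 goes against the rise seen with compound 2. No evidence is at hand that accounts for this difference between the hexyl chain and the other two groups.

The compounds shown leave open whether a shorter chain such as propyl or a longer chain such as octyl or decyl would give a lower or a higher number than hexyl, and so how the values in this assay depend on chain length. They also leave open whether a hexyl chain ending in an amine or a carboxylic acid would keep a number as low as that of compound 3.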